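Oxetane-Bearing Tail in Place of Cyclobutylmethyl

A few compounds are considered here, and "the series" means these few. Any claim that something is new, unique, unknown or untested is made for them only; others in the source may bear on it.

Three compounds share one core and differ only in the group on the amide nitrogen. In a functional assay on HEK293 cells for positive allosteric modulation of metabotropic glutamate receptor 5 (Rattus norvegicus), read by fluorescence and calcium flux (a lower number here means a smaller maximal response, a higher number a larger maximal response), compound 1 `C[C@H](NC(=O)c1ccc(C#Cc2cccc(F)c2)cn1)C(C)(C)C` gives 70.8%, compound 2 `CCCNC(=O)c1ccc(C#Cc2cccc(F)c2)cn1` gives 65.9%, and compound 3 `O=C(NCC1CCC1)c1ccc(C#Cc2cccc(F)c2)cn1` gives 68.1%. Compound 3 stands between the other two, yet all three lie within the scatter of one another, as a number 2.7 percentage points lower from compound 1 to compound 3 (within the scatter) and a number 2.2 percentage points higher from compound 2 to compound 3 (within the scatter) show. Compound 4 `CC1(CCNC(=O)c2ccc(C#Cc3cccc(F)c3)cn2)COC1` carries (3-methyloxetan-3-yl)methyl in place of cyclobutyl on a saturated chain carbon bound to an amide-type nitrogen. For the measured compounds named here, the earlier change on that same carbon, a number 2.2 percentage points higher from compound 2 to compound 3 (within the scatter), did not move the number beyond the scatter, though no measured compound holds a four-membered ring with a hetero atom. A step of no consequence is therefore expected, a number 2.1 percentage points lower from compound 3 to compound 4 (within the scatter). Compound 4 is estimated at 66%, between 54% and 78%.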

Compound 4, largest response reached (reported as efficacy), in percent of the reference or control that the assay uses: 65.7%
For compound 4 the middle estimate is 0.3 percentage points above the measured one; low and high end bracket the measured number.
By their numbers in this assay, from the lowest: compounds 4, 2, 3 and 1 (each within the scatter of the next).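

Replacing cyclobutylmethyl with 2-(3-methyloxetan-3-yl)ethyl on the amide-type nitrogen puts a four-membered ring with a hetero atom and a hydrogen-bond acceptor into the tail, yet the maximal response in this assay stays within the scatter (a number 2.4 percentage points lower from compound 3 to compound 4 (within the scatter)). The same holds against the propyl tail (a number 0.2 percentage points lower from compound 2 to compound 4 (within the scatter)) and the 1,2,2-trimethylpropyl tail (a number 5.1 percentage points lower from compound 1 to compound 4 (within the scatter)). No available evidence explains why these four tails read alike. As far as these compounds go, whether a tail ending in an amine or a carboxylic acid would also stay within the scatter remains open.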